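Bromo to methylsulfanyl on the cinnamamide ring

A few compounds are considered here, and "the series" means these few. Any claim that something is new, unique, unknown or untested is made for them only; others in the source may bear on it.

Compound 2 `CCCc1cc(N)c2cc(NC(=O)/C=C/c3ccc(Br)cc3)ccc2n1` gives 93 nM in a functional assay on HEK293 cells for activation of melanin-concentrating hormone receptor 1 (Homo sapiens), read by inositol phosphate accumulation (on this read-out lower numbers stand for an effect already at smaller amounts and higher numbers for an effect only at larger amounts of compound), and stands lowest of the two numbers recorded, with compound 1 `CCCc1ccc(/C=C/C(=O)Nc2ccc3nc(CCC)cc(N)c3c2)cc1` at 3600 nM. Compound 3 `CCCc1cc(N)c2cc(NC(=O)/C=C/c3ccc(SC)cc3)ccc2n1` differs from compound 2 by methylsulfanyl in place of bromo on an aromatic carbon. Among the measured compounds shown here, the only measured step touching this position, a 39-fold lower number from compound 1 to compound 2 (1.59 log units; beyond the scatter), showed that what sits there matters greatly, but no step covers methylsulfanyl itself. A moderate shift toward a higher number, within or near the scatter, is therefore expected for compound 3, giving an estimated 1.9-fold higher number from compound 2 to compound 3 (0.29 log units; within the scatter). Compound 3 is estimated at 180 nM, in the range 50 nM to 700 nM.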

Compound 3, half-maximal effective concentration: 71 nM
Compound 3: the middle estimate sits 2.5-fold (0.40 log units) above what was measured; the measured number falls inside the stated range.
By their numbers in this assay, from the lowest: compounds 3 and 2 (each within the scatter of the next); then compound 1.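

Methylsulfanyl and bromo cannot be told apart at this position in this assay, with a 1.3-fold lower number from compound 2 to compound 3 (0.12 log units; within the scatter) and so a change that stays within the scatter. The large step away from propyl also recurs, with a 51-fold lower number from compound 1 to compound 3 (1.71 log units; beyond the scatter) and so shows that it is not confined to bromo among the groups compared here. No evidence is available to explain why propyl stands apart from these two groups.

Still open, from the compounds shown here alone, is how an amine, a carboxylic acid or a longer sulfur-linked chain such as ethylsulfanyl would read at this position.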